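This account rests on a few compounds, and the source may have more. Where it says the series, first, only, none or still open, it means among the compounds named here.

Measured so far, in a functional assay on microsomes from aorta for inhibition of Thromboxane-A synthase (Homo sapiens), in the presence of a further agent that is not named here; a lower number here means a stronger inhibitor, a higher number a weaker inhibitor:
- compound 3 `C/C(=C/c1ccc(Cc2cccnc2)n1C)C(=O)O`: 50 nM
- compound 1 `C/C(=C/c1ccc(Cc2cccnc2)n1C(C)C)C(=O)O`: 2100 nM
- compound 2 `C/C(=C/c1ccc(Cc2cccnc2)n1-c1ccccc1)C(=O)O`: 24000 nM

Compound 3 carries a methyl on the aromatic nitrogen and gives the lowest number of the three in this assay; its steps to the other two are both beyond the scatter. Compound 4 `C/C(=C/c1ccc(Cc2cccnc2)n1CC(C)(C)C)C(=O)O` differs from compound 3 by tert-butyl in place of hydrogen on a saturated chain carbon bound to an aromatic nitrogen, which is methyl to neopentyl when read one bond further out.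

For the measured compounds named here, two measured steps bear on this: a 42-fold lower number from compound 1 to compound 3 (1.62 log units; beyond the scatter) and a 480-fold lower number from compound 2 to compound 3 (2.68 log units; beyond the scatter). Both replace a larger substituent on the aromatic nitrogen with methyl and both are large drops. The step to compound 4 runs the other way, from methyl to a larger group, so the number is expected to rise. Compound 4 is expected to land around 3000 nM, a step of a 60-fold higher number from compound 3 to compound 4 (1.78 log units; beyond the scatter), with a range of 500 nM to 20000 nM.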

Compound 4, half-maximal inhibitory concentration: 78000 nM
The estimate for compound 4 lay 26-fold (1.41 log units) below the measured number, outside the stated range (above it).
By their numbers in this assay, from the lowest: compound 3; then compound 1; then compound 2; then compound 4.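

In this assay the change to neopentyl on the aromatic nitrogen gives a 1600-fold higher number from compound 3 to compound 4 (3.19 log units; beyond the scatter) and a 37-fold higher number from compound 1 to compound 4 (1.57 log units; beyond the scatter) and also a 3.3-fold higher number from compound 2 to compound 4 (0.51 log units; beyond the scatter) so the high end of the series is set by compound 4 and not by the phenyl of compound 2. Compound 3 and compound 4 both have a saturated chain carbon bound to an aromatic nitrogen, so that feature alone does not keep the number low, and the tert-butyl carried on that carbon is enough to lose nearly all the inhibition seen with methyl. Nothing available explains these rises.

Going by these compounds, whether ethyl, a longer unbranched chain such as n-butyl, or plain hydrogen on the aromatic nitrogen stays close to compound 3 remains open. The same goes for a hydroxyethyl or aminoethyl chain there.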